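Side-chain swap at the amide-bearing carbon: compound 3 to 4

The source may hold more compounds than are shown below. What is called first, only, known or untested is meant among the compounds shown, and "the series" means these compounds.

The series shares the core of compound 1 `COC(=O)CCNC(=O)Cn1cc(C2=C(c3c[nH]c4ccccc34)C(=O)N(C)C2=O)c2ccccc21` and varies the substituent on a saturated chain carbon bound to an amide-type nitrogen and a carbonyl carbon. In a functional assay on Bel-7402 cells (Homo sapiens) for cytotoxicity, read by MTT assay, with a stated time of 24 h (on this read-out lower numbers stand for stronger inhibition and higher numbers for weaker inhibition), compound 1 gives 28400 nM. Compound 2 `COC(=O)[C@@H](C)NC(=O)Cn1cc(C2=C(c3c[nH]c4ccccc34)C(=O)N(C)C2=O)c2ccccc21` gives 9340 nM, so that a 3.0-fold lower number from compound 1 to compound 2 (0.48 log units; beyond the scatter). Compound 3 `CC[C@H](C)[C@@H](NC(=O)Cn1cc(C2=C(c3c[nH]c4ccccc34)C(=O)N(C)C2=O)c2ccccc21)C(=O)OC` reaches only the assay limit, recorded as > 100000 nM for compound 3; on the numbers shown it stands as the weakest of the three, since an at least 3.5-fold higher number from compound 1 to compound 3 (0.54 log units; beyond the scatter) and an at least 10-fold higher number from compound 2 to compound 3 (1.02 log units; beyond the scatter), both beyond the scatter.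

Compound 4 `COC(=O)C[C@@H](NC(=O)Cn1cc(C2=C(c3c[nH]c4ccccc34)C(=O)N(C)C2=O)c2ccccc21)C(=O)OC` is not yet measured. Relative to compound 3 the change is (methoxycarbonyl)methyl in place of sec-butyl on a saturated chain carbon bound to an amide-type nitrogen and a carbonyl carbon. The step that bears most directly on it is the one in which sec-butyl entered in place of methyl, where an at least 10-fold higher number from compound 2 to compound 3 (1.02 log units; beyond the scatter); compound 4 removes that sec-butyl again, but installs a group unlike methyl, so the size of the reversal is uncertain. Because compound 3 sits at the limit (the limit of > 100000 nM in this assay, at which 1 of the 3 values shown sits), the starting point of the step is itself known only as a bound. A lower number for compound 4 is expected, with the expected step of an at least 5.0-fold lower number from compound 3 to compound 4 (0.69 log units; beyond the scatter). Compound 4 is estimated at 20000 nM, within 5000 nM to 100000 nM.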

Compound 4, half-maximal inhibitory concentration: 9360 nM
Estimate against measurement, compound 4: 2.1-fold (0.33 log units) above; the measured number falls inside the stated range.
By their numbers in this assay, from the lowest: compounds 2 and 4 (each within the scatter of the next); then compound 1. At a limit, above all of these: compound 3.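

In this assay, the saturated chain carbon bound to an amide-type nitrogen and a carbonyl carbon proves to tolerate a substituent with more heavy atoms than sec-butyl, since (methoxycarbonyl)methyl gives an at least 10-fold lower number from compound 3 to compound 4 (1.02 log units; beyond the scatter), so heavy-atom count alone does not follow the read-out across methyl, sec-butyl and (methoxycarbonyl)methyl. The size of that step is only a bound, with compound 3 standing at a limit of the assay: the limit of > 100000 nM in this assay, at which 1 of the 4 values shown sits. Methoxycarbonyl in place of hydrogen on the methyl of the earlier side chain gives a 1.0-fold higher number from compound 2 to compound 4 (0.00 log units; within the scatter), so that this addition leaves no readable change, while the comparison with the shared 2-(methoxycarbonyl)ethyl compound gives a 3.0-fold lower number from compound 1 to compound 4 (0.48 log units; beyond the scatter).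

On these data alone, whether a carboxylic acid in place of the methoxycarbonyl of compound 4, or a longer chain such as 2-(methoxycarbonyl)ethyl on the same carbon, would keep the number of compound 4 remains open. Also open, as far as these compounds go, is whether an ethyl or an isobutyl at this carbon would behave like methyl or like sec-butyl, and what the opposite configuration at this carbon would give.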